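Swapping a halogen at the far end of compound 2

The source may hold more compounds than are shown below. What is called first, only, known or untested is meant among the compounds shown, and "the series" means these compounds.

Two coumarin-containing hydrazides have been measured so far in a functional assay on Ehrlich cells (Mus musculus) for cytotoxicity, read by trypan blue exclusion, with a stated time of 48 h; a higher number here means a weaker inhibitor, a lower number a stronger inhibitor. Compound 1 `COc1ccc(C(=O)c2cc(C)ccc2OCC(=O)NNC(=O)c2cc3ccccc3oc2=O)cc1` gives 41200 nM. Compound 2 `Cc1ccc(OCC(=O)NNC(=O)c2cc3ccccc3oc2=O)c(C(=O)c2ccc(Br)cc2)c1`, which carries a bromo group in place of the methoxy group, gives 91100 nM. For the measured compounds named here, compound 2 therefore stands at the highest of the two numbers seen so far, and the only step known, a 2.2-fold higher number from compound 1 to compound 2 (0.34 log units; beyond the scatter), is a modest one.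

Compound 3 `Cc1ccc(OCC(=O)NNC(=O)c2cc3ccccc3oc2=O)c(C(=O)c2ccc(F)cc2)c1` is not yet measured. It differs from compound 2 in a single way: fluoro in place of bromo on an aromatic carbon. Going by the values given here, the one measured step that touches the same position is the modest one from compound 1 to compound 2, so the group at that position moved the number only a little. Among the compounds with values here, no pair measured so far compares fluoro with bromo directly, so any expectation rests on that single neighbouring step.

The number for compound 3 in this assay is expected to stay close to that of its neighbour, with a small shift towards a lower number, giving a 1.5-fold lower number from compound 2 to compound 3 (0.18 log units; within the scatter). Compound 3 is thus estimated at 60000 nM, within a range from 25000 nM to 150000 nM.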

Compound 3, half-maximal inhibitory concentration: 43400 nM
The estimate for compound 3 lay 1.4-fold (0.14 log units) above the measured number, and the stated range covers the measured number.
By their numbers in this assay, from the lowest: compounds 1 and 3 (each within the scatter of the next); then compound 2.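

In this assay, for the compounds shown here, the first direct comparison of two halogens at this position gives a 2.1-fold lower number from compound 2 to compound 3 (0.32 log units; beyond the scatter), so fluoro and bromo are not interchangeable here, even though the two groups have the same count of heavy atoms. Going by these compounds alone, the other new step, a 1.1-fold higher number from compound 1 to compound 3 (0.02 log units; within the scatter), puts fluoro and methoxy within the scatter of each other, which leaves bromo as the one group of the three that stands apart and makes the earlier step from methoxy to bromo look like a mark of bromo rather than of losing methoxy. No outside measurement bears on this result, so the data show the pattern without explaining it.

Going by these compounds, whether chloro, another halogen, would sit with fluoro or with bromo remains open, as does whether an amine or a carboxylic acid on this same aromatic carbon would move the number further than these modest steps do. On these data alone, it is also open whether the change from 4-bromophenyl to 4-fluorophenyl would act in the same way on a different core, as it is seen here on one core only.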